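This account rests on a few compounds, and the source may have more. Where it says the series, first, only, none or still open, it means among the compounds named here.

Working notes on the series.

Compound 2 `COc1ccc(F)cc1CNCCCNc1ccnc2cc(CCC(C)C)ccc12` serves as the reference point. Among the compounds with values here, in an ADME assay on HepG2 cells (Homo sapiens) for cytotoxicity, read by luminescence, CellTiter-Glo and ATP content, with a stated time of 72 h (a higher number here means that more compound is needed for the effect, a lower number that less compound is needed), compound 2 gives 890 nM, the lowest of the three numbers so far.

Compound 1 `COc1cccc(CNCCCNc2ccnc3cc(CCC(C)C)ccc23)c1O` carries the change 2-hydroxy-3-methoxyphenyl in place of 5-fluoro-2-methoxyphenyl on a saturated chain carbon bound to an amine nitrogen relative to compound 2. In this assay compound 1 gives 5390 nM, and the step is a 6.1-fold higher number from compound 2 to compound 1 (0.78 log units; beyond the scatter).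

Compound 3 `COc1ccc(F)cc1CNCCCNc1ccnc2cc(-c3ccc(C(F)(F)F)cc3)ccc12` differs from compound 2 in the core, as 4-(trifluoromethyl)phenyl in place of isopentyl on an aromatic carbon. In this assay compound 3 gives 5190 nM, with the step of a 5.8-fold higher number from compound 2 to compound 3 (0.77 log units; beyond the scatter). The numbers for compound 1 and compound 3 lie within the scatter of each other, so no order between them is claimed.

Compound 4 `COc1cccc(CNCCCNc2ccnc3cc(-c4ccc(C(F)(F)F)cc4)ccc23)c1O` is not yet measured. It stands to compound 3 as compound 1 stands to compound 2: the change is 2-hydroxy-3-methoxyphenyl in place of 5-fluoro-2-methoxyphenyl on a saturated chain carbon bound to an amine nitrogen, on the same place as before, so it is the same change, now made on the core of compound 3 rather than that of compound 2. Within the data shown here, only one earlier instance of this change exists in the set, so its transfer to a second core is untested.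

Among the measured compounds shown here, the step from compound 3 to compound 4 is expected to be a 2.9-fold higher number from compound 3 to compound 4 (0.46 log units; beyond the scatter), resting on the single prior instance a 6.1-fold higher number from compound 2 to compound 1 (0.78 log units; beyond the scatter) in compound 1, tempered because compound 3 already gives 5190 nM and the upper range of such a cytotoxicity read-out may be approached. For compound 4 the estimated value in this assay is 15000 nM, with a range from 5000 nM to 45000 nM.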

Compound 4, half-maximal effective concentration: 2210 nM
For compound 4 the middle estimate is 6.8-fold (0.83 log units) above the measured one; measured number below the stated range.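

The same exchange does not carry over between the two cores in this assay: 2-hydroxy-3-methoxyphenyl in place of 5-fluoro-2-methoxyphenyl gives a 2.3-fold lower number from compound 3 to compound 4 (0.37 log units; beyond the scatter), whereas the earlier step on the isopentyl core went the other way: the same change on two cores in this assay, a 6.1-fold higher number (0.78 log units; beyond the scatter) from compound 2 to compound 1 and a 2.3-fold lower number (0.37 log units; beyond the scatter) from compound 3 to compound 4, 14-fold (1.15 log units) apart, beyond the scatter of two such steps

Read along the other edge of the set, 4-(trifluoromethyl)phenyl in place of isopentyl gives a 2.4-fold lower number from compound 1 to compound 4 (0.39 log units; beyond the scatter) with the 2-hydroxy-3-methoxyphenyl group present, and this also reverses the direction seen with the 5-fluoro-2-methoxyphenyl group: the same change on two cores in this assay, a 5.8-fold higher number (0.77 log units; beyond the scatter) from compound 2 to compound 3 and a 2.4-fold lower number (0.39 log units; beyond the scatter) from compound 1 to compound 4, 14-fold (1.15 log units) apart, beyond the scatter of two such steps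

Both comparisons rest on the same set of four compounds, so they are one finding seen from two sides: the effect of each change in this read-out depends on the group at the other place, and neither step can be carried to a new core on its own, but the data do not show what lies behind this reversal or how far it extends.

Going by these compounds, it remains open whether the reversal persists with other groups on the aromatic carbon, such as an unsubstituted phenyl or a shorter alkyl chain. On these data alone, it is equally open whether a benzyl group bearing only a hydroxy or only a methoxy, or a longer linking chain, would follow compound 1 and compound 4 or compound 2 and compound 3.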